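A few compounds are considered here, and "the series" means these few. Any claim that something is new, unique, unknown or untested is made for them only; others in the source may bear on it.

Measured in a functional assay on U-87MG ATCC cells for antiproliferative activity against U-87 MG (Homo sapiens), read by spectrophotometry, with a stated time of 2 days; a lower number here means a stronger inhibitor of growth, a higher number a weaker inhibitor of growth:
- Compound 1 `Cc1ccc(Nc2ncc(C(F)(F)F)c(N3Cc4cccc(N(C)S(C)(=O)=O)c4C3)n2)cc1C`: > 30000 nM, a limit
- Compound 2 `COc1ccc(C(F)(F)F)cc1Nc1ncc(C(F)(F)F)c(N2Cc3cccc(N(C)S(C)(=O)=O)c3C2)n1`: > 30000 nM, a limit
- Compound 3 `Cc1ccc(Nc2ncc(C(F)(F)F)c(N3Cc4cccc(N(C)S(C)(=O)=O)c4C3)n2)c(Cl)c1`: > 30000 nM, a limit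

Compound 3 has no exact number and stands at the limit of > 30000 nM in this assay, at which 3 of the 3 values shown sit. The change to compound 4 `COc1cc(Nc2ncc(C(F)(F)F)c(N3Cc4cccc(N(C)S(C)(=O)=O)c4C3)n2)c(OC)cc1Cl` is this: 4-chloro-2,5-dimethoxyphenyl in place of 2-chloro-4-methylphenyl on a nitrogen on an aromatic ring.

Going by the values given here, three measured steps bear on it, as each swaps the group on that same nitrogen: a step that the two limits leave unreadable from compound 1 to compound 2, a step that the two limits leave unreadable from compound 1 to compound 3 and a step that the two limits leave unreadable from compound 2 to compound 3. None has a readable size, and none gave a number in this assay. So no clear step in either direction is expected, and another limit is the likeliest result.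

The expected change is a number no higher from compound 3 to compound 4 (the limit leaves the size open). Compound 4 is estimated at 30000 nM, with an expected range of 10000 nM to 60000 nM.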

Compound 4, concentration for 50% growth inhibition: 6200 nM
Beside the measured number, compound 4's estimate is 4.8-fold (0.68 log units) above it; measured number outside the range, below it.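

In this assay, the group on this nitrogen now proves able to move the result: 4-chloro-2,5-dimethoxyphenyl gives an at least 4.8-fold lower number from compound 3 to compound 4 (0.68 log units; beyond the scatter) and an at least 4.8-fold lower number from compound 2 to compound 4 (0.68 log units; beyond the scatter) and an at least 4.8-fold lower number from compound 1 to compound 4 (0.68 log units; beyond the scatter) on the same shared core. Compound 4 alone has an exact number, so each size is only a minimum, because the other three compounds have only a limit: the limit of > 30000 nM in this assay, at which 3 of the 4 values shown sit.

Whether the two methoxy groups, the chlorine or their combination accounts for these steps stays open. So does what an amine or a carboxylic acid on this phenyl ring would give.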